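The source may report more compounds than this note shows. Statements on the series, on what has been measured and on what is new or still open speak of the compounds shown alone.

Compound 1 `C=C=CCN(C)Cc1ccccc1`: > 48 umol/kg
Compound 2 `C=C=C(CN)Cc1ccc(C)cc1`: > 38 umol/kg
Compound 3 `C=C=C(CN)Cc1ccc(OC)cc1`: 39 umol/kg

Of the compounds shown here, three have been measured in an assay on forebrain for inhibition of Monoamine oxidase (Mus musculus); on this read-out lower numbers stand for an effect already at smaller amounts and higher numbers for an effect only at larger amounts of compound. For compound 1 the value > 48 umol/kg is a limit of the assay and not a number. For compound 2 the value > 38 umol/kg is likewise only a limit. Compound 3 alone gives a true number, 39 umol/kg in this assay. Among the measured pairs only one differs in a single place, and that step, a step that the limit leaves unreadable from compound 2 to compound 3, cannot be read in size because one of its two values sits at the limit (the limit of > 38 umol/kg in this assay, at which 1 of the 3 values shown sits).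

The unmeasured compound 4 `C=C=CCNCc1ccccc1` is reached from compound 1 by a change in one place: hydrogen in place of methyl on an amine nitrogen. None of the measured steps touches the amine nitrogen, so no measured step bears directly on this change, and the only single-place step shown is itself unreadable. With compound 1 standing at a limit (the limit of > 48 umol/kg in this assay, at which 1 of the 3 values shown sits), there is no firm footing for the direction of the step either way. The step from compound 1 to compound 4 is therefore expected to be an at least 1.0-fold lower number from compound 1 to compound 4 (0.02 log units; that floor lies within the scatter), which is no more than a guess near the region where compound 1 sits. Compound 4 is estimated at 45 umol/kg, within a wide range from 10 umol/kg to 200 umol/kg in this assay.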

Compound 4, dose for half-maximal effect: > 51 umol/kg
Compound 4: no number, only a limit; the forecaster's own chance of this, stated with the estimate: 50%; at least 1.1-fold (0.05 log units) between middle value and limit.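

In this assay compound 4 gives > 51 umol/kg, which is a limit of the assay and not a number. Compound 1 also stands only at a limit, so the step between compound 1 and compound 4 cannot be read. The compounds shown leave open how far, and in which direction, hydrogen in place of methyl on an amine nitrogen moves the read-out.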